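The compounds below may be only part of what the source reports. "The series", "measured", "known", "first", "only" and "open" are said of these compounds alone.

Working notes on the series. Going by the values given here, in an ADME assay on RAW264.7 cells (Mus musculus) for cytotoxicity, read by luminescence and CellTiter-Glo, with a stated time of 18 h, tested at 20 uM (on this read-out lower numbers stand for a stronger effect and higher numbers for a weaker effect at the one concentration tested), compound 1 `C=C1CC[C@H]2C(C)(C)CCC[C@]2(C)[C@H]1C/C=C1\CC(O)OC1=O` gives 79% and compound 2 `C=C1CC[C@H]2C(C)(C)CCC[C@]2(C)[C@H]1C/C=C1\CC(OC)OC1=O` gives 100%; the one step measured, a number 21 percentage points higher from compound 1 to compound 2 (beyond the scatter), leaves compound 2 with the higher of the two numbers. Compound 3 `C=C1CC[C@H]2C(C)(C)CCC[C@]2(C)[C@H]1C/C=C1\CC(OCC)OC1=O` differs from compound 2 by methyl in place of hydrogen on a saturated chain carbon bound to an oxygen on a saturated carbon. That step bears no resemblance to the measured one beyond lying at the same oxygen, so it is taken as uninformative, and the expected change from compound 2 to compound 3 is a number 2 percentage points lower from compound 2 to compound 3 (within the scatter), none beyond the scatter. Compound 3 is therefore expected at 98% in this assay, estimated between 85% and 110%.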

Compound 3, a percentage reported as activity, at one concentration (the size of the read-out at that concentration, not a potency): 96.3%
The estimate for compound 3 lay 1.7 percentage points above the measured number; the measured number falls inside the stated range.
By their numbers in this assay, from the lowest: compound 1; then compounds 3 and 2 (each within the scatter of the next).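

Going from methoxy to ethoxy gives a number 3.7 percentage points lower from compound 2 to compound 3 (within the scatter) in this assay, so the added methyl on this saturated chain carbon has no effect that can be told from the scatter. Ethyl in place of hydrogen on the oxygen gives a number 17.3 percentage points higher from compound 1 to compound 3 (beyond the scatter), which puts compound 3 with compound 2 and apart from compound 1 . Nothing at hand explains this shift on replacing the hydrogen on the oxygen. Still open, going by these compounds, is whether a longer chain, a phenyl group or an amine on this oxygen would stay level with compound 2 and compound 3 or move the number.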